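Removing One Methoxy Group From Two Related Compounds

The source may hold more compounds than are shown below. What is called first, only, known or untested is meant among the compounds shown, and "the series" means these compounds.

Compound 1 `COc1cc(-c2cc(/C=C/C(=O)c3ccc(N)cc3)[nH]n2)cc(OC)c1OC` was tested in a functional assay on SF-268 cells (Homo sapiens) for inhibition, read by sulforhodamine B assay, with a stated time of 48 h (a lower number here means a stronger inhibitor of growth, a higher number a weaker inhibitor of growth), where compound 1 gave 1690 nM. Compound 2 `COc1ccc(-c2cc(/C=C/C(=O)c3ccc(N)cc3)[nH]n2)cc1OC` carries a single change relative to compound 1, (hydrogen in place of methoxy on an aromatic carbon), and in this assay compound 2 gave 1890 nM. The step of a 1.1-fold higher number from compound 1 to compound 2 (0.05 log units; within the scatter) shows that this change left growth inhibition essentially unmoved. Compound 3 `COc1cc(C(=O)/C=C/c2cc(-c3cc(OC)c(OC)c(OC)c3)n[nH]2)cc(OC)c1OC` is built on a different core; the difference between the core of compound 3 and the core of compound 1 is not broken down here. In this assay compound 3 gave 1940 nM. Compound 4 `COc1ccc(-c2cc(/C=C/C(=O)c3cc(OC)c(OC)c(OC)c3)[nH]n2)cc1OC` has not yet been measured. It differs from compound 3 by hydrogen in place of methoxy on an aromatic carbon, the same change as between compound 1 and compound 2, at a place described in the same words. The earlier step of a 1.1-fold higher number from compound 1 to compound 2 (0.05 log units; within the scatter) lay within the scatter. On that basis a small step is expected for compound 4, a 1.1-fold higher number from compound 3 to compound 4 (0.03 log units; within the scatter). Compound 4 is thus estimated at 2100 nM, with a likely range from 1000 nM to 4500 nM.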

Compound 4, concentration for 50% growth inhibition: 1680 nM
The estimate for compound 4 lay 1.3-fold (0.10 log units) above the measured number; measured number inside the range.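

In this assay, putting hydrogen in place of methoxy on the second core gave a 1.2-fold lower number from compound 3 to compound 4 (0.06 log units; within the scatter), so growth inhibition stayed essentially unchanged. The change therefore behaved alike on both cores, with no sign of a difference between them: the same change on two cores in this assay, a 1.1-fold higher number (0.05 log units; within the scatter) from compound 1 to compound 2 and a 1.2-fold lower number (0.06 log units; within the scatter) from compound 3 to compound 4, 1.3-fold (0.11 log units) apart, within the scatter of two such steps. Among these compounds, this shows only that the swap did little on these two cores in this one cell assay; it does not show that the same would hold on any other core, or that a change with a larger effect would carry over equally well.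

The compounds shown leave open what other groups would do at this place. A hydroxyl group or a chlorine atom in place of the methoxy, for example, might or might not carry across the two cores in the same way.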